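Swapping Hydroxyl Positions on a Shared Core

The compounds below may be only part of what the source reports. "The series", "measured", "known", "first", "only" and "open" are said of these compounds alone.

Compound 1: `Oc1ccc(-c2cc(-c3ccccc3O)cc(-c3ccccc3O)n2)cc1` — 0.3%
Compound 2: `Oc1ccc(-c2cc(-c3cccc(O)c3)nc(-c3cccc(O)c3)c2)cc1` — 0%

Both compounds were tested in an assay on isolated protein for inhibition of DNA topoisomerase 1 (Homo sapiens), with a stated time of 30 min, tested at 100 uM; a higher number here means more inhibition at the concentration tested (going by the name of the read-out), a lower number less inhibition. In this assay compound 1 gives 0.3%, and compound 2 gives 0%. These two numbers lie within the scatter of each other, so compound 1 cannot be set apart from compound 2: both show essentially no inhibition at the concentration tested.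

Compound 3 is `Oc1ccc(-c2cc(-c3ccc(O)cc3)nc(-c3ccccc3O)c2)cc1`. It differs from compound 1 in this way: 4-hydroxyphenyl in place of 2-hydroxyphenyl on an aromatic carbon. Within the data shown here, no step between two measured compounds is available to calibrate such a change. Compound 2, which carries only hydroxyphenyl groups arranged differently on the same core, also shows nothing, so no movement beyond the scatter is expected in this assay. The expected step of a number 0.3 percentage points lower from compound 1 to compound 3 (within the scatter) is therefore close to none. Compound 3 is estimated to give 0%, with a range from 0% to 8%.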

Compound 3, a percentage reported as inhibition, at one concentration (the size of the read-out at that concentration, not a potency): 0%
Compound 3: the middle estimate sits on the measured number at the digits printed; the range from low to high includes it.
By their numbers in this assay, from the lowest: compounds 2, 3 and 1 (each within the scatter of the next).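

In this assay, among these compounds, putting 4-hydroxyphenyl in place of 2-hydroxyphenyl on the aromatic carbon opposite the ring nitrogen gives a number 0.3 percentage points lower from compound 1 to compound 3 (within the scatter) and offers the first comparison of two compounds that differ in one place. At this position, moving the hydroxyl around the attached ring does not bring inhibition out of the scatter, and both compounds stay close to nothing, so the step cannot show whether this position matters for inhibition. No measurement at hand offers a reason for this lack of inhibition.

On these data alone, whether an amine or a carboxylic acid on this carbon, in place of the hydroxyphenyl group, would give real inhibition stays open. So does the effect of changing the two other hydroxyphenyl groups on the shared core.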